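A few compounds are considered here, and "the series" means these few. Any claim that something is new, unique, unknown or untested is made for them only; others in the source may bear on it.

Compound 3 `O=C1NC(=O)/C(=C\c2ccc(OCC(=O)N3N=C(c4ccc(F)cc4F)CC3c3ccco3)cc2)S1` gives 15000 nM in an assay on cells for inhibition of histone deacetylase 4 (Homo sapiens), read by fluorescence, with a stated time of 30 min (on this read-out higher numbers stand for weaker inhibition and lower numbers for stronger inhibition), the highest number among the three measured; compound 1 `O=C1NC(=O)/C(=C\c2ccc(OCC(=O)N3N=C(c4ccccc4)CC3c3ccc(F)cc3)cc2)S1` gives 1700 nM and compound 2 `O=C1NC(=O)/C(=C\c2ccc(OCC(=O)N3N=C(c4ccc(F)cc4)CC3c3ccc(F)cc3)cc2)S1` gives 1400 nM, both well below it. Compound 4 `O=C1NC(=O)/C(=C\c2ccc(OCC(=O)N3N=C(c4ccc(F)cc4F)CC3c3ccc(F)cc3)cc2)S1` differs from compound 3 by 4-fluorophenyl in place of furan-2-yl on a saturated ring carbon. For the measured compounds named here, the only measured step, a 1.2-fold lower number from compound 1 to compound 2 (0.08 log units; within the scatter), concerns the other aryl group and does not bear on this change. Going by the values given here, no measured step covers the swap of furan-2-yl for 4-fluorophenyl on the saturated ring carbon; what is known is that compounds 1 and 2, which both carry 4-fluorophenyl there, sit far lower than compound 3. A large downward step is therefore expected, a 7.5-fold lower number from compound 3 to compound 4 (0.88 log units; beyond the scatter). Compound 4 is estimated at 2000 nM, within 700 nM to 6000 nM.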

Compound 4, half-maximal inhibitory concentration: 1500 nM
For compound 4 the middle estimate is 1.3-fold (0.12 log units) above the measured one, within the range that was stated.
By their numbers in this assay, from the lowest: compounds 2, 4 and 1 (each within the scatter of the next); then compound 3.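

With the rest of the structure held constant, 4-fluorophenyl in place of furan-2-yl on the saturated ring carbon gives a 10-fold lower number from compound 3 to compound 4 (1.00 log units; beyond the scatter) in this assay, the first matched read of this position. With 4-fluorophenyl held there, the group on the carbon with a double bond to nitrogen shows no effect beyond the scatter: a 1.1-fold higher number from compound 2 to compound 4 (0.03 log units; within the scatter) and a 1.1-fold lower number from compound 1 to compound 4 (0.05 log units; within the scatter) are both small. No evidence on the cause of the change at the saturated ring carbon is available.

Still open, going by these compounds, is where an amine, a carboxylic acid or a longer alkyl chain on the saturated ring carbon would fall relative to 4-fluorophenyl and furan-2-yl.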